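The compounds below may be only part of what the source reports. "The series", "measured", "known", "first", "only" and "open" are said of these compounds alone.

Compound 1 `O=C1O[C@H]([C@@H](O)Cn2cc(CNS(=O)(=O)c3ccc(Cl)cc3F)nn2)C(OCc2ccccc2)=C1OCc1ccccc1`: 20700 nM
Compound 2 `O=C1O/C(=C\Cn2cc(-c3ccc(Br)cc3)nn2)C(OCc2ccccc2)=C1OCc1ccccc1`: 24300 nM

Both numbers come from a functional assay on HeLa cells (Homo sapiens) for antiproliferative activity, read by MTT assay, with a stated time of 72 h; on this read-out lower numbers stand for stronger inhibition and higher numbers for weaker inhibition. Compound 1 has the lower of the two numbers, but its gap to compound 2 lies within the scatter, so neither compound stands apart from the other. Compound 3 `CCCCc1cn(C[C@H](O)[C@H]2OC(=O)C(OCc3ccccc3)=C2OCc2ccccc2)nn1` has not yet been measured. It differs from compound 1 in one place: propyl in place of ((4-chloro-2-fluorophenyl)sulfonyl)amino on a saturated chain carbon bound to an aromatic carbon. Going by the values given here, no step between two measured compounds isolates this change, so its effect is unknown. Because compound 1 gives 20700 nM and compound 2 gives 24300 nM, both at weak inhibition, the step of a 1.4-fold higher number from compound 1 to compound 3 (0.16 log units; within the scatter) is expected to be modest, if anything toward a higher number. Compound 3 is accordingly estimated at 30000 nM, with a range from 8000 nM to 110000 nM.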

Compound 3, half-maximal inhibitory concentration: 18100 nM
The estimate for compound 3 lay 1.7-fold (0.22 log units) above the measured number, within the range that was stated.
By their numbers in this assay, from the lowest: compounds 3, 1 and 2 (each within the scatter of the next).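

In this assay, putting propyl in place of ((4-chloro-2-fluorophenyl)sulfonyl)amino on a saturated chain carbon bound to an aromatic carbon gives a 1.1-fold lower number from compound 1 to compound 3 (0.06 log units; within the scatter). This position therefore tolerates the loss of the whole sulfonylamino group and its aromatic ring, with no difference this read-out can resolve. Nothing available explains this result.

On these data alone, it remains open whether an amine, a carboxylic acid or a longer chain at this place would give a number beyond the scatter. As far as these compounds go, it also remains open whether any group here can affect the number at all.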